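This account rests on a few compounds, and the source may have more. Where it says the series, first, only, none or still open, it means among the compounds named here.

Measured so far in an ADME assay on HeLa cells (Homo sapiens) for cytotoxicity, read by ATP content, with a stated time of 3 days; on this read-out lower numbers stand for higher toxicity in this test and higher numbers for lower toxicity in this test:
- compound 1 `Cn1ccc(-n2c(=O)n(Cc3cc4cc(Cl)ccc4n3CCCC#N)c3cnccc32)n1`: > 50000 nM, a limit of the assay
- compound 2 `Cc1ccc(-n2c(=O)n(Cc3cc4cc(Cl)ccc4n3CCCC#N)c3cnccc32)cc1`: > 50000 nM, a limit of the assay

Compound 2 stands only at a limit of this assay, not at a number. Compound 1 likewise gives only a limit in this assay. Among the compounds with values here, the one measured step, a step that the two limits leave unreadable from compound 1 to compound 2, therefore cannot be read for size, as both of its ends are limits; the evidence on this series is the limit of > 50000 nM in this assay, at which 2 of the 2 values shown sit.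

The next compound, compound 3 `N#CCCCn1c(Cn2c(=O)n(-c3ccc(C(=O)O)cc3)c3ccncc32)cc2cc(Cl)ccc21`, differs from compound 2 in one place: carboxy in place of methyl on an aromatic carbon. No measured step bears readably on this change, since the only comparison available is a step that the two limits leave unreadable from compound 1 to compound 2 and both of its values are limits; no contribution of the carboxy group to the read-out can be drawn from what is shown.

On this footing the expected step in this assay is a number no higher from compound 2 to compound 3 (the limit leaves the size open), that is, none beyond the scatter. Compound 3 is estimated at 50000 nM, with a range from 20000 nM to 150000 nM, and most probably another limit rather than a number.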

Compound 3, half-maximal cytotoxic concentration: > 50000 nM
Compound 3: only a limit was reported (the forecaster's own chance of this, stated with the estimate: 85%); the middle value lies on the limit itself.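

Compound 3, like compound 1 and compound 2, gives only a limit in this assay, so neither new step to compound 3 can be read for size: the limit of > 50000 nM in this assay, at which 3 of the 3 values shown sit.

The compounds shown leave open whether the group on the aromatic nitrogen has any effect on the half-maximal cytotoxic concentration.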